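Longer amine groups and a possible further gain in potency

A few compounds are considered here, and "the series" means these few. Any claim that something is new, unique, unknown or untested is made for them only; others in the source may bear on it.

In a functional assay on LNCaP cells (Homo sapiens) for antiproliferative activity, read by WST assay, with a stated time of 3 days (on this read-out higher numbers stand for weaker inhibition and lower numbers for stronger inhibition), compound 1 (`CCCCCCCOc1c(-c2cc(OC)c(OC)c(OC)c2)oc2ccccc2c1=O`) gives > 50000 nM as its reading, and this is a limit of the assay and not a number. Compound 2 (`CCN(CC)CCCOc1c(-c2cc(OC)c(OC)c(OC)c2)oc2ccccc2c1=O`), which carries diethylamino, reads 37600 nM on the same scale. Compound 3 (`CCCN(CCC)CCCOc1c(-c2cc(OC)c(OC)c(OC)c2)oc2ccccc2c1=O`), which carries dipropylamino, reads 17900 nM there.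

Compound 4 (`CCCCCN(CCCCC)CCCCCOc1c(-c2cc(OC)c(OC)c(OC)c2)oc2ccccc2c1=O`) has not yet been measured. Its difference from compound 1 is this: dipentylamino in place of ethyl on a saturated chain carbon, five bonds along the chain from an oxygen on an aromatic ring; in words, dipentylamino in place of ethyl on a saturated chain carbon, five bonds along the chain from an oxygen on an aromatic ring.

Within the data shown here, three measured steps bear on this change. The first is an at least 1.3-fold lower number from compound 1 to compound 2 (0.12 log units; that floor lies within the scatter) and so says little alone. The second is an at least 2.7-fold lower number from compound 1 to compound 3 (0.44 log units; beyond the scatter) and is clearer. The third is a 2.1-fold lower number from compound 2 to compound 3 (0.32 log units; beyond the scatter) and shows longer groups on the amine going with a lower number across these compounds. Among the measured compounds shown here, no measured step covers the longer chain that compound 4 also has, so the expectation stays loose. A further drop, meaning stronger inhibition, is expected in this assay, in line with compound 3 at 17900 nM here.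

The estimated step is an at least 6.2-fold lower number from compound 1 to compound 4 (0.79 log units; beyond the scatter) as an expectation only. For compound 4 the expected value is 8000 nM with an estimated range from 2000 nM to 30000 nM in this assay overall.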

Compound 4, half-maximal inhibitory concentration: 7900 nM
The estimate for compound 4 lay 1.0-fold (0.01 log units) above the measured number; the measured number falls inside the stated range.
By their numbers in this assay, from the lowest: compound 4; then compound 3; then compound 2. At a limit, above all of these: compound 1.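

Placing dipentylamino on a saturated chain carbon, five bonds along the chain from an oxygen on an aromatic ring, gives an at least 6.3-fold lower number from compound 1 to compound 4 (0.80 log units; beyond the scatter) in this assay. Among these compounds, the earlier amines all sat three bonds along the chain, so this is the first sign that an amine further out can also give a lower number than compound 1, which has no amine at all. Compound 1 gives > 50000 nM, which is a limit of the assay and not a number: the limit of > 50000 nM in this assay, at which 1 of the 4 values shown sits.

The step from compound 1 is therefore a floor rather than a full measure of the change, and the true difference may be larger. Chain length and the groups on the nitrogen differ together here, so the compounds shown cannot say how much of the drop belongs to each; a dipentylamino group three bonds along the chain, or a diethylamino group five bonds along it, would pull the two apart. From the compounds shown here alone, whether a longer group such as dihexylamino, or a ring amine such as piperidine, would bring the number down further also stays open.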